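A few compounds are considered here, and "the series" means these few. Any claim that something is new, unique, unknown or untested is made for them only; others in the source may bear on it.

The measured compounds:
compound 1, `Cc1nc2c(CSc3ccccc3)cccn2c1C`, inhibition 31%
compound 2, `Cc1nc2c(OCc3ccccc3)cccn2c1CO`, inhibition 57%

Of the compounds shown here, two built on a shared core have been tested in a functional assay on the whole organism (stomach) for inhibition, with Canis familiaris (Canis lupus familiaris) as the target, at a dose of 1 mg/kg by the intravenous route; on this read-out lower numbers stand for a weaker effect and higher numbers for a stronger effect at the one dose given. Compound 1 gives 31%. Compound 2 gives 57%, the higher of the two numbers, and its gap to compound 1 lies beyond the scatter of repeated measurements, so on these two results compound 2 stands as the stronger one.

Compound 3, `Cc1nc2c(OCc3ccccc3)cccn2c1C`, has not yet been measured in this assay. It arises from compound 2 by one change: hydrogen in place of hydroxy on a saturated chain carbon bound to an aromatic carbon. Within the data shown here, compound 1 and compound 2 differ from each other in two places at once, so no single step between measured compounds shows what this change alone does to the read-out; the two values can only be compared as they are.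

With that in mind, the step is expected to be a modest fall from compound 2 to compound 3, of about a number 12 percentage points lower from compound 2 to compound 3 (beyond the scatter), close to the edge of the usual scatter. Compound 3 is therefore estimated to give 45%, within a range from 20% to 70%.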

Compound 3, a percentage reported as inhibition, in the whole organism at one dose (the size of the read-out at that dose, not a potency): 90%
Compound 3: the middle estimate sits 45 percentage points below what was measured, and the stated range ends below it.
By their numbers in this assay, from the lowest: compound 1; then compound 2; then compound 3.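

In this assay, replacing hydroxymethyl with methyl, which puts hydrogen in place of hydroxy on a saturated chain carbon bound to an aromatic carbon, gives a number 33 percentage points higher from compound 2 to compound 3 (beyond the scatter). Among these compounds, this is the first single change read at this place, and it shows that the effect at the one dose given depends strongly on what stands there. The hydroxy group is not needed for the effect in this pair, as the simpler methyl compound reads higher without it, but no measurement shown here bears on why the read-out changes.

With only this one swap read at this place, the compounds shown do not tell whether another group there, such as an amine, a carboxylic acid or a longer chain like ethyl, would raise or lower the effect. Also open, as far as these compounds go, is whether the rise holds at other doses, since a reading at one dose shows the size of an effect at that dose and not the potency of the compound.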